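The source may report more compounds than this note shows. Statements on the series, on what has been measured and on what is new or still open speak of the compounds shown alone.

Measured in a functional assay on PC-3 cells (Homo sapiens) for antiproliferative activity, read by MTT assay, with a stated time of 24 h; a lower number here means a stronger inhibitor, a higher number a weaker inhibitor:
- compound 1 `CCn1c(C(=O)N[C@@H](C)C(=O)OC)ccc1C(CC)(CC)c1ccc(OCS(=O)(=O)c2ccccc2)c(C)c1`: > 50000 nM (a limit)
- compound 2 `CCn1c(C(=O)N[C@@H](CC(=O)OC)C(=O)OC)ccc1C(CC)(CC)c1ccc(OCS(=O)(=O)c2ccccc2)c(C)c1`: 6490 nM
- compound 3 `CCn1c(C(=O)NCCNC(=O)OC(C)(C)C)ccc1C(CC)(CC)c1ccc(OCS(=O)(=O)c2ccccc2)c(C)c1`: > 50000 nM (a limit)

Compound 3 stands at the limit of > 50000 nM in this assay, at which 2 of the 3 values shown sit, so it has no number of its own. Compound 4 `CCN(CC)CCNC(=O)c1ccc(C(CC)(CC)c2ccc(OCS(=O)(=O)c3ccccc3)c(C)c2)n1CC` carries diethylamino in place of (tert-butoxycarbonyl)amino on a saturated chain carbon, two bonds along the chain from an amide-type nitrogen.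

For the measured compounds named here, no measured step makes this exchange. The nearest evidence is that changes on the amide-type nitrogen side can move the result: an at least 7.7-fold lower number from compound 1 to compound 2 (0.88 log units; beyond the scatter) and an at least 7.7-fold higher number from compound 2 to compound 3 (0.88 log units; beyond the scatter). By contrast, a step that the two limits leave unreadable from compound 1 to compound 3. Going by the values given here, with only three compounds, this supports no general pattern. Since compound 3 sits at a limit, a readable change in this assay can only be toward a lower number, and a modest step of that kind is expected, though compound 4 may well remain at the limit. The expected step is an at least 2.5-fold lower number from compound 3 to compound 4 (0.39 log units; beyond the scatter). For compound 4, the estimate is 20000 nM, with an expected range of 6000 nM to 60000 nM.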

Compound 4, half-maximal inhibitory concentration: 7130 nM
Beside the measured number, compound 4's estimate is 2.8-fold (0.45 log units) above it; the range from low to high includes it.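

In this assay, diethylamino in place of (tert-butoxycarbonyl)amino on a saturated chain carbon, two bonds along the chain from an amide-type nitrogen, gives an at least 7.0-fold lower number from compound 3 to compound 4 (0.84 log units; beyond the scatter) and shows that a change at this position alone can bring a compound of the series off the limit. The 2-(diethylamino)ethyl group gives an at least 7.0-fold lower number from compound 1 to compound 4 (0.84 log units; beyond the scatter) and also a 1.1-fold higher number from compound 2 to compound 4 (0.04 log units; within the scatter), so in this assay it cannot be told apart from the 1,2-bis(methoxycarbonyl)ethyl group on the same nitrogen. Compound 1 and compound 3 each stand at a limit, not at a number: the limit of > 50000 nM in this assay, at which 2 of the 4 values shown sit.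

As far as these compounds go, what a primary amine in place of diethylamino, or a longer chain carrying the diethylamino group, would give stays open. Also open, from the compounds shown here alone, is whether a carboxylic acid in place of the methoxycarbonyl groups of compound 2 would hold its result.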